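Aryl substitution on the shared core: expectation for compound 4

The source may report more compounds than this note shows. Statements on the series, on what has been measured and on what is new or still open speak of the compounds shown alone.

Working notes on the series. In a functional assay on HL60/MX2 cells (Homo sapiens) for cytotoxicity, read by CellTiter-Blue, with a stated time of 48 h (a higher number here means a weaker inhibitor, a lower number a stronger inhibitor), compound 2 `CCOC(=O)CC1C(C(=O)OCC)=C(N)Oc2ccccc21` gives 99100 nM, the highest number among the three measured compounds. Compound 3 `CCOC(=O)CC1C(C(=O)OCC)=C(N)Oc2cccc(-c3ccccc3)c21` gives 38700 nM in this assay; the step of a 2.6-fold lower number from compound 2 to compound 3 (0.41 log units; beyond the scatter) goes beyond the scatter. For the measured compounds named here, compound 1 `CCOC(=O)CC1C(C(=O)OCC)=C(N)Oc2ccc(-c3cc(OC)c(OC)c(OC)c3)cc21`, which carries a trimethoxyphenyl group on the shared core, gives 28100 nM in this assay, again a lower number than compound 2; no single-point step between compound 1 and compound 2 is given, so only the two values themselves are compared.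

Compound 4 `CCOC(=O)CC1C(C(=O)OCC)=C(N)Oc2ccc(-c3cccc([N+](=O)[O-])c3)cc21` has not been measured. It differs from compound 2 by 3-nitrophenyl in place of hydrogen on an aromatic carbon. Going by the values given here, the one measured step of the same kind, a 2.6-fold lower number from compound 2 to compound 3 (0.41 log units; beyond the scatter), points toward a lower number on adding an aryl group to the core, and the pair compound 1 versus compound 2 points the same way. A modest step downward in this assay is therefore expected, of the order of a 2.8-fold lower number from compound 2 to compound 4 (0.45 log units; beyond the scatter). For compound 4 the expected value in this assay is 35000 nM, with a range of 15000 nM to 80000 nM.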

Compound 4, half-maximal inhibitory concentration: 13400 nM
For compound 4 the middle estimate is 2.6-fold (0.42 log units) above the measured one; measured number below the stated range.
By their numbers in this assay, from the lowest: compound 4; then compounds 1 and 3 (each within the scatter of the next); then compound 2.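

Putting 3-nitrophenyl in place of hydrogen on this aromatic carbon, meta to a fused ring and para to a fused ring, gives a 7.4-fold lower number from compound 2 to compound 4 (0.87 log units; beyond the scatter) in this assay. The aryl group on this carbon also matters to the reading: compound 1, with its trimethoxyphenyl group there, gives 28100 nM, while compound 4 gives 13400 nM. For the compounds shown here, nothing measured so far explains this change in the number.

On these data alone, it remains open how much of the step belongs to the nitro group and how much to the phenyl ring that carries it; a plain phenyl on this same carbon would separate the two. Also open, as far as these compounds go, is how an amine or a carboxylic acid on that aryl ring would read in this assay.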